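This account rests on a few compounds, and the source may have more. Where it says the series, first, only, none or still open, it means among the compounds named here.

Measured so far:

Compound 1 `Clc1ccc2c(NCCCOc3nccc(Cl)n3)ccnc2c1` — in a physicochemical assay for lipophilicity, read by HPLC, in phosphate buffer, measured as octanol-water partition, with a stated time of 24 h, at pH 7.4 (a higher number here means a more lipophilic compound, a lower number a more polar compound), compound 1 gives 1.04.
Compound 2 `Clc1ccc2c(NCCCCCCCCNc3nccc(Cl)n3)ccnc2c1` — in this assay compound 2 gives 1.51.
Compound 3 `Clc1ccc2c(NCCCNc3nccc(N4CCNCC4)n3)ccnc2c1` — in this assay compound 3 gives 0.102.

Compound 2 stands highest of the three numbers in this assay. Its nearest neighbour is compound 1, whose number lies lower by an amount beyond the scatter; compound 3 lies furthest, lower by a larger amount, also beyond the scatter. No pair among these three differs in only one place, so no single step can be read off from the measured set.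

Compound 4 `Clc1ccc2c(NCCCCCCCCNc3ccnc(Cl)n3)ccnc2c1` is not yet measured. It keeps every atom of compound 2 and differs only in how they are joined: 2-chloropyrimidin-4-yl in place of 4-chloropyrimidin-2-yl on an amine nitrogen. The two groups that swap match each other in every counted respect, so the change is expected to move this assay little in either direction, if at all beyond the scatter. The step from compound 2 to compound 4 is estimated at a number 0.01 log units lower from compound 2 to compound 4 (within the scatter). Compound 4 is therefore expected to give 1.5, within the range 1.1 to 1.9.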

Compound 4, distribution coefficient: 1.48
The estimate for compound 4 lay 0.02 log units above the measured number, and the stated range covers the measured number.
By their numbers in this assay, from the lowest: compound 3; then compound 1; then compounds 4 and 2 (each within the scatter of the next).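

Among these compounds, this is the first step that can be read at a single place: on an amine nitrogen whose other neighbour is a saturated chain carbon, 2-chloropyrimidin-4-yl in place of 4-chloropyrimidin-2-yl gives a number 0.03 log units lower from compound 2 to compound 4 (within the scatter) in this assay on this chain. For this pair, the arrangement of the same atoms in the chloropyrimidine therefore leaves the read-out within the scatter, so neither compound can be placed above the other. Nothing shown here accounts for this result.

On these data alone, whether the swap stays within the scatter in this assay with a longer chain, or with a methoxy group or a morpholine in place of the chlorine, remains open. A single pair also cannot show whether the same holds with an ether oxygen in place of the amine nitrogen.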